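Exchanging a pyrazolylmethyl for a cyanophenyl at the ether carbon

This account rests on a few compounds, and the source may have more. Where it says the series, first, only, none or still open, it means among the compounds named here.

Compound 3 `Cc1nn(-c2ncnc3nc[nH]c23)c2c1C(OCCn1cccn1)CC(=O)N2` has the highest number of the three measured compounds in a functional assay on HEK293 cells for agonist activity at G-protein coupled receptor 39 (Homo sapiens), read by scintillation proximity assay and inositol phosphate accumulation, with a stated time of 75 min (a higher number here means that more compound is needed for the effect, a lower number that less compound is needed), giving 2270 nM. Compound 1 `Cc1cc(C)n(CCOC2CC(=O)Nc3c2c(C)nn3-c2ncnc3nc[nH]c23)n1` gives 2000 nM, and compound 2 `Cc1nn(-c2ncnc3nc[nH]c23)c2c1C(OCc1ccccc1F)CC(=O)N2` gives 78 nM. Compound 4 `Cc1nn(-c2ncnc3nc[nH]c23)c2c1C(OCc1ccc(C#N)cc1)CC(=O)N2` differs from compound 3 by 4-cyanophenyl in place of (1H-pyrazol-1-yl)methyl on a saturated chain carbon bound to an oxygen on a saturated carbon. For the measured compounds named here, two measured steps bear on this change. The step of a 29-fold higher number from compound 2 to compound 3 (1.46 log units; beyond the scatter) shows the effect of trading an aromatic ring on the saturated chain carbon bound to an oxygen for a (1H-pyrazol-1-yl)methyl group, and a 26-fold lower number from compound 1 to compound 2 (1.41 log units; beyond the scatter) shows the mirror change from the 3,5-dimethyl-1H-pyrazol-1-yl analogue. Compound 4 again places an aromatic ring on that carbon, so a large fall in the number is expected, a 15-fold lower number from compound 3 to compound 4 (1.18 log units; beyond the scatter). For compound 4 the estimate is 150 nM, within 40 nM to 600 nM.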

Compound 4, half-maximal effective concentration: 60 nM
For compound 4 the middle estimate is 2.5-fold (0.40 log units) above the measured one, within the range that was stated.
By their numbers in this assay, from the lowest: compounds 4 and 2 (each within the scatter of the next); then compounds 1 and 3 (each within the scatter of the next).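

The step of a 38-fold lower number from compound 3 to compound 4 (1.58 log units; beyond the scatter) and the step of a 33-fold lower number from compound 1 to compound 4 (1.52 log units; beyond the scatter) show that a second benzene ring, now with a nitrile, also gives a large fall at this ether carbon, so the fall is not confined to 2-fluorophenyl. The step of a 1.3-fold lower number from compound 2 to compound 4 (0.11 log units; within the scatter) lies within the scatter, so 4-cyanophenyl and 2-fluorophenyl cannot be told apart here. No evidence is given that explains these differences. Still open, going by these compounds, is whether an amine or a carboxylic acid in place of the nitrile, or a longer chain leading to the ring, would keep the number this low.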